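A few compounds are considered here, and "the series" means these few. Any claim that something is new, unique, unknown or untested is made for them only; others in the source may bear on it.

Measured so far in a functional assay on DLD-1 cells (Homo sapiens) for antiproliferative activity, read by CellTiter-Glo, with a stated time of 72 h; a higher number here means a weaker inhibitor, a lower number a stronger inhibitor:

compound 1 `CCCC(=O)N(Cc1ccccc1)C1CCN(S(=O)(=O)c2c(C)cc(C)cc2C)CC1`: > 5000 nM
compound 2 `CC1CCN(C2CCN(S(=O)(=O)c3ccccc3-c3ccc(Cl)cc3)CC2)CC1`: 202 nM
compound 3 `C#CCOCCC1CCCCN1C1CCN(S(=O)(=O)c2ccccc2)CC1`: > 5000 nM

The value of compound 1 in this assay is a limit of the assay, > 5000 nM. Compound 3 likewise stands at a limit, > 5000 nM. Among the compounds with values here, compound 2 is the one compound with a number, giving 202 nM. Within the data shown here, compound 1 therefore stands at the limit of > 5000 nM in this assay, at which 2 of the 3 values shown sit, and no step between two measured compounds is available to guide a prediction.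

Compound 4 `CCCC(=O)NC1CCN(S(=O)(=O)c2c(C)cc(C)cc2C)CC1` differs from compound 1 in one place: hydrogen in place of benzyl on an amide-type nitrogen. Compound 1 already sits at a limit, > 5000 nM. The step that the limit leaves unreadable from compound 1 to compound 4 is expected to be none beyond the scatter, with compound 4 most likely reported again only as a limit. Compound 4 is estimated at 9000 nM, within a range of 3000 nM to 30000 nM.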

Compound 4, half-maximal inhibitory concentration: > 5000 nM
Compound 4: only a limit was reported (the forecaster's own chance of this, stated with the estimate: 85%); the middle value lies beyond the limit too.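

Within the data shown here, compound 1 and compound 4 each give only a limit in this assay, so no step between them can be read: the limit of > 5000 nM in this assay, at which 3 of the 4 values shown sit. As far as these compounds go, whether hydrogen in place of benzyl on an amide-type nitrogen changes activity in this assay stays open.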